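Chloro for methyl on the anilino ring of compound 1

The compounds below may be only part of what the source reports. "The series", "measured", "known", "first", "only" and "open" are said of these compounds alone.

Measured in an assay on HEK293 cells for displacement of a labelled ligand from Neuronal acetylcholine receptor; alpha3/beta4 (Homo sapiens); a lower number here means a stronger inhibitor, a higher number a weaker inhibitor:
compound 1 `Cc1ccc(Nc2cncc(N3CC4CC(C3)N4)c2)cc1` gives 1.4 nM
compound 2 `Oc1ccc(Nc2ccc(N3CC4CC(C3)N4)cn2)cc1` gives 165 nM
compound 3 `Clc1cccc(Nc2ccc(N3CC4CC(C3)N4)cn2)c1` gives 4.8 nM

Among these three, compound 1 has the lowest number, and its steps to compound 3 and compound 2 both lie beyond the scatter. Compound 4 `Clc1cccc(Nc2cncc(N3CC4CC(C3)N4)c2)c1` differs from compound 1 in one place: 3-chlorophenyl in place of 4-methylphenyl on a nitrogen on an aromatic ring. For the measured compounds named here, the only measured step touching this part of the molecule is a 34-fold lower number from compound 2 to compound 3 (1.54 log units; beyond the scatter), which concerns a different core and a hydroxyl rather than a methyl as the group that leaves. Compound 3, which already carries 3-chlorophenyl, shows a number close to that of compound 1. The exchange of methyl for chlorine is therefore expected to give at most a small step, a 1.4-fold higher number from compound 1 to compound 4 (0.15 log units; within the scatter), and compound 4 is estimated at 2 nM, with a range from 0.7 nM to 6 nM.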

Compound 4, inhibition constant: 293 nM
For compound 4 the middle estimate is 150-fold (2.17 log units) below the measured one; the measured number lies above the stated range.
By their numbers in this assay, from the lowest: compound 1; then compound 3; then compounds 2 and 4 (each within the scatter of the next).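

In this assay, 3-chlorophenyl in place of 4-methylphenyl on the core of compound 1 is a large loss, a 210-fold higher number from compound 1 to compound 4 (2.32 log units; beyond the scatter) and so this position does not treat the two groups alike. The same 3-chlorophenyl group gives compound 3 4.8 nM on its own core and compound 4 293 nM on the core of compound 1, so the value of this group does not carry over from one core to the other here. Nothing measured here accounts for the size of this step. Still open, from the compounds shown here alone, is whether the chlorine or its place on the ring matters more, a question that 4-chlorophenyl and 3-methylphenyl on the core of compound 1 would separate.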